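Swapping the pyrazine for a triazole on the shared core

The compounds below may be only part of what the source reports. "The series", "measured", "known", "first", "only" and "open" are said of these compounds alone.

Measured so far:
- compound 1 `c1ccc(-c2ccc(CCc3nc(CC4CCCC4)c[nH]3)cc2)nc1`: 22 nM
- compound 2 `CCC(C)(C)Cc1c[nH]c(CCc2ccc(-c3cnccn3)cc2)n1`: 11 nM
- compound 3 `CCC(C)(C)Cc1c[nH]c(CCc2ccc(N3CCCCC3)cc2)n1`: 28 nM

In a functional assay on HEK293 cells for agonist activity at Bombesin receptor subtype-3 (Mus musculus), read by luminescence and calcium flux, with a stated time of 10 min (a higher number here means that more compound is needed for the effect, a lower number that less compound is needed), compound 2 gives 11 nM and sits at the low end of the three numbers. Compound 1 is close to it, within the usual scatter, while compound 3 lies beyond the scatter, as the step of a 2.5-fold higher number from compound 2 to compound 3 (0.41 log units; beyond the scatter) shows. The unmeasured compound 4 `CCC(C)(C)Cc1c[nH]c(CCc2ccc(-n3ccnn3)cc2)n1` differs from compound 2 in one place: 1H-1,2,3-triazol-1-yl in place of pyrazin-2-yl on an aromatic carbon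

Among the compounds with values here, only one measured step bears on this change. From compound 2 to compound 3 the same pyrazin-2-yl was replaced by piperidin-1-yl and the number rose, a 2.5-fold higher number from compound 2 to compound 3 (0.41 log units; beyond the scatter), a modest step. The group entering in compound 4 is, like the group that leaves, a small aromatic ring, so the change is smaller in kind than the step to compound 3. Compound 4 is therefore expected to show at most a small rise in this assay, a 1.6-fold higher number from compound 2 to compound 4 (0.21 log units; within the scatter), which may stay within the scatter. Compound 4 is estimated at 18 nM, with a range of 7 nM to 50 nM.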

Compound 4, half-maximal effective concentration: 57 nM
Compound 4: the middle estimate sits 3.2-fold (0.50 log units) below what was measured; measured number above the stated range.
By their numbers in this assay, from the lowest: compounds 2, 1 and 3 (each within the scatter of the next, the first and the last beyond it); then compound 4.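

In this assay, the position para to a large group proves sensitive to which small aromatic ring it carries: 1H-1,2,3-triazol-1-yl in place of pyrazin-2-yl gives a step beyond the scatter (a 5.2-fold higher number from compound 2 to compound 4 (0.71 log units; beyond the scatter)). Being aromatic is thus not enough to hold the number at this position, as the triazole also stands above the non-aromatic piperidin-1-yl (a 2.0-fold higher number from compound 3 to compound 4 (0.31 log units; beyond the scatter)). Nothing available explains this rise.

The compounds shown leave open whether the rise follows the five-membered ring, the count of ring nitrogens or the attachment of the ring through nitrogen. A pyrazol-1-yl ring, which is also five-membered and joined through nitrogen but holds one nitrogen fewer, would begin to separate these readings, and a plain phenyl ring would show what the ring nitrogens contribute.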